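The compounds below may be only part of what the source reports. "The series", "measured", "known", "first", "only" and "open" are said of these compounds alone.

Measured so far in a functional assay on CCRF-CEM cells (Homo sapiens), with a stated time of 3 days; a higher number here means a weaker inhibitor, a lower number a stronger inhibitor:
- compound 1 (`C=C1C=CCO[C@@H]1n1ccc(NC(=O)c2ccccc2)nc1=O`) : 432000 nM
- compound 2 (`O=C1C=CCO[C@@H]1n1ccc(O)nc1=O`) : 82000 nM
- compound 3 (`O=C1C=CCO[C@@H]1n1cc(C(F)(F)F)c(O)nc1=O`) : 39000 nM

Of these three, compound 3 has the lowest number, 39000 nM. Next is compound 4 (`Cc1cn([C@H]2OCC=CC2=O)c(=O)nc1O`), with methyl in place of trifluoromethyl on an aromatic carbon. Within the data shown here, one measured step bears on this: trifluoromethyl in place of hydrogen on an aromatic carbon gave a 2.1-fold lower number from compound 2 to compound 3 (0.32 log units; beyond the scatter), a modest change. Methyl is therefore expected to give a small move towards a higher number in this assay, ending between the values of compound 3 and compound 2. The expected step is a 1.5-fold higher number from compound 3 to compound 4 (0.19 log units; within the scatter). For compound 4 the estimated value is 60000 nM, with an expected range of 25000 nM to 140000 nM.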

Compound 4, half-maximal inhibitory concentration: 104000 nM
The estimate for compound 4 lay 1.7-fold (0.24 log units) below the measured number, within the range that was stated.
By their numbers in this assay, from the lowest: compound 3; then compounds 2 and 4 (each within the scatter of the next); then compound 1.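

At the aromatic carbon ortho to a hydroxy group, methyl does not match trifluoromethyl in this assay, giving a 2.7-fold higher number from compound 3 to compound 4 (0.43 log units; beyond the scatter) on that exchange. Methyl in place of hydrogen gives a 1.3-fold higher number from compound 2 to compound 4 (0.10 log units; within the scatter), so of the groups shown at this position, only trifluoromethyl stands apart from hydrogen. No measurement on hand explains the gap between these two groups.

Open, going by these compounds, is whether an amine, a carboxylic acid or a nitrile at this carbon would track with trifluoromethyl or with methyl and hydrogen. A longer chain here is also untested in these compounds.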